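Adding bromo to compound 2: a small step expected

A few compounds are considered here, and "the series" means these few. Any claim that something is new, unique, unknown or untested is made for them only; others in the source may bear on it.

Measured in a functional assay on A-431 cells (Homo sapiens) for cytotoxicity, read by MTT assay, with a stated time of 48 h; a lower number here means a stronger inhibitor, a higher number a weaker inhibitor:
- Compound 1 `COc1cc(-c2ocnc2-c2cc(Br)c(OC)c(OC)c2)ccc1SC`: 410 nM
- Compound 2 `COc1cc(-c2ocnc2-c2cc(OC)c(OC)c(OC)c2)ccc1SC`: 430 nM

Compound 2 stands level with compound 1, and the two numbers lie within the scatter. Compound 3 `COc1cc(-c2ncoc2-c2cc(Br)c(SC)c(OC)c2)cc(OC)c1OC` is compound 2 with bromo in place of hydrogen on an aromatic carbon, ortho to a methylsulfanyl group (bromo in place of hydrogen on an aromatic carbon). Within the data shown here, the only measured step involving bromo is a different swap, methoxy in place of bromo, and it was small: a 1.0-fold higher number from compound 1 to compound 2 (0.02 log units; within the scatter). It is weak guidance, but no change beyond the scatter is expected in this assay. The expected step is a 1.2-fold higher number from compound 2 to compound 3 (0.07 log units; within the scatter). Compound 3 is estimated at 500 nM, within an expected range of 120 nM to 2500 nM.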

Compound 3, half-maximal inhibitory concentration: > 20000 nM
Compound 3: only a limit was reported; the forecaster's own chance of this, stated with the estimate: 5%; middle value at least 40-fold (1.60 log units) from the limit.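

The swap of methoxy for bromo on the other ring, a 1.0-fold higher number from compound 1 to compound 2 (0.02 log units; within the scatter), gave no sign that this carbon ortho to a methylsulfanyl group would be so sensitive. Here, in this assay, adding one bromo gives a large loss: an at least 46-fold higher number from compound 2 to compound 3 (1.66 log units; beyond the scatter). For compound 3, > 20000 nM is a limit of the assay and not a number, so the full size of the step stays unknown: the limit of > 20000 nM in this assay, at which 1 of the 3 values shown sits.

Going by these compounds, whether the loss belongs to bromo itself or to any group on this carbon stays open. Fluoro, an amine or a hydroxyl group here could answer that.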